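This account rests on a few compounds, and the source may have more. Where it says the series, first, only, none or still open, it means among the compounds named here.

Compound 2 `O=c1c(CSC(=S)N2CCCC2)coc2ccccc12` carries a pyrrolidin-1-yl group on a thiocarbonyl carbon. In a functional assay on HeLa cells (Homo sapiens) for antiproliferative activity, read by MTT assay, with a stated time of 72 h (on this read-out higher numbers stand for weaker inhibition and lower numbers for stronger inhibition), compound 2 gives > 25000 nM, which is a limit of the assay rather than a number. Compound 2 thus stands at the limit of > 25000 nM in this assay, at which 1 of the 3 values shown sits. Compound 3 `CN1CCN(C(=S)SCc2coc3ccccc3c2=O)CC1` gives 5900 nM, and the step of an at least 4.2-fold lower number from compound 2 to compound 3 (0.62 log units; beyond the scatter) changes only the amine part of the thiocarbonyl group. Compound 1 `COc1ccc2occ(CSC(=S)N(C(C)C)C(C)C)c(=O)c2c1` gives 5400 nM, yet it differs from compound 2 in two places at once. Compound 4 `COc1ccc2occ(CSC(=S)N3CCCC3)c(=O)c2c1` arises from compound 2 by methoxy in place of hydrogen on an aromatic carbon. Among the measured compounds shown here, no measured step alters only this position, so the direction of the change is open. Compound 4 is expected to give about 15000 nM, within 4500 nM to 50000 nM, and the expected step of an at least 1.6-fold lower number from compound 2 to compound 4 (0.22 log units; that floor lies within the scatter) may remain within the scatter.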

Compound 4, half-maximal inhibitory concentration: 12100 nM
Compound 4: middle estimate off by 1.2-fold (0.09 log units), on the high side; the measured number falls inside the stated range.
By their numbers in this assay, from the lowest: compounds 1 and 3 (each within the scatter of the next); then compound 4. At a limit, above all of these: compound 2.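

With the amine part held as pyrrolidin-1-yl, methoxy in place of hydrogen on the aromatic carbon gives an at least 2.0-fold lower number from compound 2 to compound 4 (0.31 log units; beyond the scatter), so this position does affect the read-out. With the methoxy core held constant, the amine part can now be read alone: pyrrolidin-1-yl in place of diisopropylamino gives a 2.2-fold higher number from compound 1 to compound 4 (0.35 log units; beyond the scatter). The full size of the methoxy step stays unknown because the value of compound 2 is a limit rather than a number: the limit of > 25000 nM in this assay, at which 1 of the 4 values shown sits.

The compounds shown leave open whether a hydroxyl group or a chlorine atom on this carbon would act like methoxy. They also leave open whether the methoxy step would hold with 4-methylpiperazin-1-yl on the thiocarbonyl carbon.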